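Aryl urea variations on a shared quinazoline-amine scaffold

The source may report more compounds than this note shows. Statements on the series, on what has been measured and on what is new or still open speak of the compounds shown alone.

Measured compounds:
Compound 1, `COc1ccccc1NC(=O)Nc1cccc(CNc2ncnc3ccccc23)c1`: 30800 nM
Compound 2, `O=C(Nc1cccc(CNc2ncnc3ccccc23)c1)Nc1ccccc1F`: 26100 nM
Compound 3, `O=C(Nc1cccc(CNc2ncnc3ccccc23)c1)Nc1ccccc1Cl`: 18000 nM

Of the compounds shown here, three have been measured in a functional assay on A549 cells (Homo sapiens) for antiproliferative activity, read by MTT assay; on this read-out lower numbers stand for stronger inhibition and higher numbers for weaker inhibition. All three share the same core, and differ only in the group carried on the far nitrogen of the urea. Compound 3 gives the lowest of the three numbers, but its nearest neighbour, compound 2, sits only a 1.5-fold lower number from compound 2 to compound 3 (0.16 log units; within the scatter) away, and compound 1 only a 1.7-fold lower number from compound 1 to compound 3 (0.23 log units; within the scatter) away, so none of the three can be set apart from the others. The step of a 1.2-fold lower number from compound 1 to compound 2 (0.07 log units; within the scatter) tells the same story.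

Compound 4, `O=C(Nc1cccc(CNc2ncnc3ccccc23)c1)Nc1cccc(C(F)(F)F)c1`, has not yet been measured in this assay. It differs from compound 3 by 3-(trifluoromethyl)phenyl in place of 2-chlorophenyl on an amide-type nitrogen. The measured steps all concern exchanges of a single substituent on that aromatic ring, and each of them stayed within the scatter, which gives no indication that a further exchange at the same position would move the number far. Going by the values given here, nothing measured so far addresses a trifluoromethyl group, so the expectation rests on those small steps alone. The step from compound 3 to compound 4 is therefore expected to be about a 1.1-fold lower number from compound 3 to compound 4 (0.02 log units; within the scatter), with no clear direction. Compound 4 is estimated at 17000 nM, within a range from 6000 nM to 50000 nM.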

Compound 4, half-maximal inhibitory concentration: 44200 nM
Estimate against measurement, compound 4: 2.6-fold (0.41 log units) below, and the stated range covers the measured number.
By their numbers in this assay, from the lowest: compounds 3, 2, 1 and 4 (each within the scatter of the next, the first and the last beyond it).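

In this assay, going by these compounds alone, putting 3-(trifluoromethyl)phenyl in place of 2-chlorophenyl on the amide-type nitrogen gives the first step in this set that lies beyond the scatter (a 2.5-fold higher number from compound 3 to compound 4 (0.39 log units; beyond the scatter)), so the group on this nitrogen can shift the number, though only modestly. This holds for one pair alone: the same group in place of 2-fluorophenyl gives (a 1.7-fold higher number from compound 2 to compound 4 (0.23 log units; within the scatter)) and in place of 2-methoxyphenyl gives (a 1.4-fold higher number from compound 1 to compound 4 (0.16 log units; within the scatter)), both within the scatter, so compound 4 stands apart from compound 3 only. No measurement shown accounts for the step from compound 3 to compound 4.

That step exchanges both the substituent and its place on the ring, as the two group names show, and the compounds shown cannot separate those two changes. Also open, going by these compounds, is how the number would respond to an amine or a carboxylic acid on that ring, or to a longer chain in place of the ring, and whether any group on this nitrogen could reach far lower numbers than compound 3 gives (18000 nM).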